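The source may hold more compounds than are shown below. What is called first, only, known or untested is meant among the compounds shown, and "the series" means these compounds.

Measured so far in a physicochemical assay for solubility, measured as kinetic solubility; a lower number here means a less soluble compound, a higher number a more soluble compound:
compound 1 `CC(=O)Nc1cc(-c2ccc(N(C)C(=O)c3c(F)cccc3Cl)c(N3CC4CC4C3)c2)n(C2CCC2)n1`: 0.5 ug/mL
compound 2 `CC(=O)Nc1cc(-c2ccc(N(C)C(=O)c3c(F)cccc3Cl)c(N3CC4CC4C3)c2)n(C(C)C2CC2)n1`: 0.5 ug/mL
compound 3 `CC(=O)Nc1cc(-c2ccc(N(C)C(=O)c3c(Cl)cccc3Cl)c(N3CC4CC4C3)c2)n(C(C)C)n1`: 0.8 ug/mL

All three compounds share the core and differ only at the group on the aromatic nitrogen and at the aryl on the carbonyl carbon. The numbers of compound 1, compound 2 and compound 3 differ from one another by less than the scatter, so compound 3 cannot be set apart from the other two on this assay; all three sit at very low solubility.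

Compound 4 `CC(=O)Nc1cc(-c2ccc(N(C)C(=O)c3c(C)cccc3F)c(N3CC4CC4C3)c2)n(C(C)C)n1` is not yet measured. Its difference from compound 3 is 2-fluoro-6-methylphenyl in place of 2,6-dichlorophenyl on a carbonyl carbon, that is, 2-fluoro-6-methylphenyl in place of 2,6-dichlorophenyl on the carbonyl carbon.

Among the measured compounds shown here, the only measured step, no change at the digits printed from compound 1 to compound 2 (within the scatter), changes the group on the aromatic nitrogen, not the aryl on the carbonyl, so it does not bear directly on this change; no measured pair varies the aryl on the carbonyl carbon. There is therefore no basis in the data for a step beyond the scatter, and the step from compound 3 to compound 4 is expected as a 1.1-fold lower number from compound 3 to compound 4 (0.06 log units; within the scatter).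

For compound 4 the estimate is 0.7 ug/mL, with a range of 0.3 ug/mL to 1.6 ug/mL.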

Compound 4, solubility: 17 ug/mL
Compound 4: the middle estimate sits 24-fold (1.39 log units) below what was measured, and the stated range ends below it.
By their numbers in this assay, from the lowest: compounds 1, 2 and 3 (each within the scatter of the next); then compound 4.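

Working notes on the series: in this assay the aryl on the carbonyl carbon, whose other neighbour is an amide-type nitrogen, now shows a large response, with 2-fluoro-6-methylphenyl in place of 2,6-dichlorophenyl giving a 21-fold higher number from compound 3 to compound 4 (1.33 log units; beyond the scatter) and a step beyond the scatter. The earlier measured change, on the aromatic nitrogen, gave no change at the digits printed from compound 1 to compound 2 (within the scatter) and so did not show that this series can leave the very low range of the read-out, and here that happens with no change in the heavy-atom count of the group, which stays at 8 on both sides, and with no hydrogen-bond donor, hydrogen-bond acceptor or net charge on either group. Nothing available here accounts for the size of this step.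

Both chlorines leave together in this exchange, so the separate contributions of the methyl and the fluorine stay unresolved, as does whether the step carries over to compounds with cyclobutyl or 1-cyclopropylethyl on the aromatic nitrogen. From the compounds shown here alone, how this aryl would respond to a methoxy group, an amine or a carboxylic acid also remains open.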